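This account rests on a few compounds, and the source may have more. Where it says the series, first, only, none or still open, it means among the compounds named here.

Compound 1 `O=c1nc(N2CCN(NC3CCCCC3)CC2)sc2c([N+](=O)[O-])cc(C(F)(F)F)cc12` and compound 2 `CON=C1CCC(N(C)N2CCN(c3nc(=O)c4cc(C(F)(F)F)cc([N+](=O)[O-])c4s3)CC2)CC1` share one core and differ only on an amine nitrogen in a ring. In an ADME assay on Vero cells (Chlorocebus sabaeus) for cytotoxicity, read by MTT assay, with a stated time of 72 h (a lower number here means that less compound is tolerated, a higher number that more compound is tolerated), compound 1 gives a limit of the assay, > 64 ug/mL. In this assay compound 2 likewise returns only a limit, > 64 ug/mL. The step that the two limits leave unreadable from compound 1 to compound 2 can therefore not be sized, since (the limit of > 64 ug/mL in this assay, at which 2 of the 2 values shown sit). Compound 2 thus stands at the limit of this assay, with no numeric value that would place it against compound 1.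

Compound 3 `O=c1nc(N2CCN(NCc3cccc(C(F)(F)F)c3)CC2)sc2c([N+](=O)[O-])cc(C(F)(F)F)cc12` is the next exchange at the same position, away from compound 2: a group of 12 heavy atoms (8 carbon, 1 nitrogen, 3 fluorine; one six-membered aromatic ring of carbon only) in place of a group of 11 heavy atoms (8 carbon, 2 nitrogen, 1 oxygen; one six-membered non-aromatic ring of carbon only), on an amine nitrogen in a ring. Among the compounds with values here, the only measured step on this position, a step that the two limits leave unreadable from compound 1 to compound 2, is unreadable, so neither direction nor size is established for exchanges of this kind; the one indication is that both measured compounds sit at the limit. For compound 3 the expectation in this assay is estimated at 80 ug/mL, with a range from 32 ug/mL to 200 ug/mL. The implied step that the limit leaves unreadable from compound 2 to compound 3 is expected to be none beyond the scatter, most likely with a limit reported again.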

Compound 3, half-maximal cytotoxic concentration: > 64 ug/mL
Compound 3 was reported as a limit; the forecaster's own chance of this, stated with the estimate: 65%; the middle value is on the limit's open side.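

In this assay, within the data shown here, compound 3 also returns only a limit, so no step among compound 1, compound 2 and compound 3 can be read: the limit of > 64 ug/mL in this assay, at which 3 of the 3 values shown sit. The compounds shown leave open whether any group at this amine nitrogen gives a numeric value in this assay, and how these three groups rank against one another.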